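This account rests on a few compounds, and the source may have more. Where it says the series, first, only, none or still open, it means among the compounds named here.

Compound 1 `O=C(c1ccccc1)c1ccc2nc(NCCC3CCCNC3)[nH]c2c1` gave > 30000 nM in an ADME assay on CRL8155 cells (Homo sapiens) for cytotoxicity, read by resazurin assay, with a stated time of 72 h; on this read-out lower numbers stand for an effect already at smaller amounts and higher numbers for an effect only at larger amounts of compound.
Compound 2 `O=C(CCCC1CCNCC1)Nc1nc2ccc(C(=O)c3ccccc3)cc2[nH]1` gave > 30000 nM in this assay.
Compound 3 `Nc1nc2ccc(C(=O)c3ccccc3)cc2n1C[C@@H]1CCCN1` gave > 30000 nM in this assay.

Each of these three values is a limit of this assay and not a measured number: the cells were still not affected at the highest amount tested. Compound 3 therefore cannot be placed above or below its two companions; all three sit together at the same ceiling, which is the limit of > 30000 nM in this assay, at which 3 of the 3 values shown sit. For the measured compounds named here, nothing among the measured compounds shows how a change to the group on the aromatic nitrogen moves the result, since no pair of them differs in only one place.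

The next compound, compound 4 `CC(C)(C)Cn1c(N)nc2ccc(C(=O)c3ccccc3)cc21`, keeps the shared core of compound 3 and changes only the side group: tert-butyl in place of pyrrolidin-2-yl on a saturated chain carbon bound to an aromatic nitrogen. The chain on the nitrogen stays, and what changes is the end of it.

With every measured value at the ceiling, the step from compound 3 to compound 4 is expected to be a number no higher from compound 3 to compound 4 (the limit leaves the size open), meaning no change beyond the scatter that can be seen. The estimate for compound 4 is 30000 nM, with a range from 10000 nM to 90000 nM, and most likely this assay will again report only a limit rather than a number.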

Compound 4, half-maximal effective concentration: > 30000 nM
Compound 4: a limit, no number; the forecaster's own chance of this, stated with the estimate: 70%; the middle value lies on the limit itself.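

For the compounds shown here, compound 3 and compound 4 both give a limit and not a number in this assay, so no step between them can be read, and all the compounds shown sit together: the limit of > 30000 nM in this assay, at which 4 of the 4 values shown sit. The compounds shown leave open whether any of them would affect these cells at larger amounts, and whether changing the group on the chain would then shift that effect.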